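Chloromethyl in place of hydroxymethyl on the free acid

The compounds below may be only part of what the source reports. "The series", "measured", "known", "first", "only" and "open" are said of these compounds alone.

Compound 3 `CC(C)[C@H]1CC[C@@](O)(CO)[C@H]2C(=O)OCC(C(=O)O)=C[C@H]12` returns only a limit in a functional assay on A-375 cells (Homo sapiens) for inhibition, with a stated time of 72 h (on this read-out higher numbers stand for weaker inhibition and lower numbers for stronger inhibition), namely > 32000 nM. That places compound 3 at the limit of > 32000 nM in this assay, at which 1 of the 3 values shown sits, so its true value is not known. The other two measured compounds carry a different substituent on the shared core: compound 1 `CC(C)[C@H]1CC[C@@]2(CO2)[C@H]2C(=O)OCC(C(=O)OCc3ccc(-c4ccc([N+](=O)[O-])cc4)o3)=C[C@H]12` gives 1640 nM and compound 2 `CC(C)[C@H]1CC[C@@](O)(CCl)[C@H]2C(=O)OCC(C(=O)OCc3ccc(-c4ccccc4)o3)=C[C@H]12` gives 4000 nM in this assay. Compound 4 `CC(C)[C@H]1CC[C@@](O)(CCl)[C@H]2C(=O)OCC(C(=O)O)=C[C@H]12` is not yet measured. It differs from compound 3 by chloro in place of hydroxy on a saturated chain carbon bound to a saturated ring carbon. Among the measured compounds shown here, no step between measured compounds is available, so the size of this change is open. The step of an at least 1.2-fold lower number from compound 3 to compound 4 (0.10 log units; that floor lies within the scatter) is expected to be modest, probably not beyond the scatter. For compound 4 an estimate of about 25000 nM is given, within 8000 nM to 64000 nM, with a fair chance that this assay again reports only a limit.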

Compound 4, half-maximal inhibitory concentration: 1310 nM
Beside the measured number, compound 4's estimate is 19-fold (1.28 log units) above it; measured number outside the range, below it.
By their numbers in this assay, from the lowest: compounds 4 and 1 (each within the scatter of the next); then compound 2. At a limit, above all of these: compound 3.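

In this assay, chloro in place of hydroxy on a saturated chain carbon bound to a saturated ring carbon gives an at least 24-fold lower number from compound 3 to compound 4 (1.38 log units; beyond the scatter), so on the free acid this position responds strongly to this change. The earlier compounds shown here offered no step at this position. Compound 3 gives only a limit, so the step is a floor and its true size remains unknown: the limit of > 32000 nM in this assay, at which 1 of the 4 values shown sits.

On these data alone, whether the gain comes from adding chloro or from losing hydroxy stays open. A methyl or a fluoro at this position would help separate the two.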